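Removing the Methyl from an Inactive Pyridylpiperazine Thiosemicarbazone

This account rests on a few compounds, and the source may have more. Where it says the series, first, only, none or still open, it means among the compounds named here.

Measured compounds:
compound 1, `Cc1cccc(/C(N)=N/NC(=S)N2CCN(c3ccccn3)CC2)n1`, > 100000 nM
compound 2, `N/C(=N\NC(=S)N1CCCCC1)c1ccccn1`, 8500 nM

In a functional assay on MCF7 cells (Homo sapiens) for cytotoxicity, read by MTT assay, with a stated time of 72 h (on this read-out lower numbers stand for stronger inhibition and higher numbers for weaker inhibition), compound 1 reaches only a limit, > 100000 nM, so its number is not known. Compound 2, `N/C(=N\NC(=S)N1CCCCC1)c1ccccn1`, gives 8500 nM in this assay. Compound 3, `N/C(=N\NC(=S)N1CCN(c2ccccn2)CC1)c1ccccn1`, has not yet been measured. It differs from compound 1 by hydrogen in place of methyl on an aromatic carbon. Because compound 1 sits at the limit of > 100000 nM in this assay, at which 1 of the 2 values shown sits, the expected step of an at least 4.0-fold lower number from compound 1 to compound 3 (0.60 log units; beyond the scatter) in this assay points towards stronger inhibition, beyond the scatter, though a limit may again be reported. Compound 3 is estimated at 25000 nM, between 5000 nM and 120000 nM.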

Compound 3, half-maximal inhibitory concentration: 13700 nM
Compound 3: the middle estimate sits 1.8-fold (0.26 log units) above what was measured; the measured number falls inside the stated range.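

In this assay the change from 6-methylpyridin-2-yl to pyridin-2-yl gives an at least 7.2-fold lower number from compound 1 to compound 3 (0.86 log units; beyond the scatter) and so shows that this carbon, next to the ring nitrogen, is sensitive: a single methyl there separates a compound at a limit from one with a measurable number. On these data alone, the full size of the step stays unknown, because the value of compound 1 is only a limit: the limit of > 100000 nM in this assay, at which 1 of the 3 values shown sits.

The compounds shown leave open how an ethyl, a methoxy or a chlorine would behave at this carbon. They also leave open whether a methyl there would have a like effect in compound 2.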